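Extending the Alkene Chain of a Diyne Alcohol

This account rests on a few compounds, and the source may have more. Where it says the series, first, only, none or still open, it means among the compounds named here.

Compound 1 `C=CCCCCCC#CC#CCO` is a straight-chain alcohol in which a pair of triple bonds sits between the hydroxyl carbon and a chain ending in a double bond. Within the data shown here, in a functional assay on A549 cells (Homo sapiens) for cytotoxicity (a lower number here means that less compound is needed, a higher number that more compound is needed for the effect), compound 1 gives 13.8 ug/mL, the highest of the two numbers measured so far. Among the measured compounds shown here, its one measured neighbour is compound 2 `C=CCCCCCC#CC#CC(O)CC(C)=O`, which in this assay gives 4.97 ug/mL; that step, a 2.8-fold lower number from compound 1 to compound 2 (0.44 log units; beyond the scatter), comes from placing a 2-oxopropyl group on a saturated chain carbon bound to an oxygen on a saturated carbon and a triple-bonded carbon, a different part of the molecule.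

Compound 3 `C=CCCCCCCCC#CC#CCO` differs from compound 1 elsewhere: but-3-en-1-yl in place of vinyl on a saturated chain carbon, five bonds along the chain from a triple-bonded carbon. For the measured compounds named here, no measured step touches this part of the chain, so there is no direct guide to its effect, and the shared core is kept. The expectation is therefore that compound 3 behaves much like compound 1, with the step of a 1.2-fold lower number from compound 1 to compound 3 (0.06 log units; within the scatter) expected to stay within the scatter. The estimate for compound 3 in this assay is 12 ug/mL, and for compound 3 the range runs from 6 ug/mL to 25 ug/mL.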

Compound 3, concentration for half-maximal effect: 3.9 ug/mL
Compound 3: the middle estimate sits 3.1-fold (0.49 log units) above what was measured; measured number below the stated range.
By their numbers in this assay, from the lowest: compounds 3 and 2 (each within the scatter of the next); then compound 1.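

The part of the chain carrying the double bond is not a silent region of the molecule. In this assay, but-3-en-1-yl in place of vinyl on a saturated chain carbon, five bonds along the chain from a triple-bonded carbon, gives a 3.5-fold lower number from compound 1 to compound 3 (0.55 log units; beyond the scatter) and so shows that this position responds to a change made entirely of carbon. The group that enters has 4 carbons against 2 in the group that leaves, with one double bond in each and no ring, hydrogen-bond donor, hydrogen-bond acceptor or net charge in either, so a simple lengthening of the chain is enough to move the number, although no measurement here bears on the cause of this step.

A single lengthening cannot show whether the number keeps falling with a longer chain such as hex-5-en-1-yl, or whether the double bond matters at all, which a saturated butyl group in the same place would test. It also leaves open how this position responds to an amine or a carboxylic acid at the chain end, and whether the longer chain and the 2-oxopropyl group work together when both are present in one molecule.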